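Phenylpropyl side-chain variation in an adenosine A2b antagonist series

This account rests on a few compounds, and the source may have more. Where it says the series, first, only, none or still open, it means among the compounds named here.

Measured compounds:
compound 1 `Nc1nc(CCCc2ccccc2)nc2cn(-c3ccccc3)nc12`: 432 nM
compound 2 `COc1cccc(CCCc2nc(N)c3nn(-c4ccccc4)cc3n2)c1`: 334 nM

Both compounds share a core and differ only on the aromatic ring at the end of the three-carbon chain. In a functional assay on CHO cells for antagonist activity at adenosine receptor A2b (Homo sapiens), read by scintillation counting and cAMP accumulation (on this read-out higher numbers stand for weaker inhibition and lower numbers for stronger inhibition), compound 1 gives 432 nM, and compound 2 gives 334 nM. Among the measured compounds shown here, the single step between them, a 1.3-fold lower number from compound 1 to compound 2 (0.11 log units; within the scatter), leaves the two numbers within the scatter of each other, so compound 2 stands level with compound 1 rather than apart from it.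

Compound 3 `Nc1nc(CCCc2ccccc2O)nc2cn(-c3ccccc3)nc12` is the next member. Relative to compound 2 it carries 2-hydroxyphenyl in place of 3-methoxyphenyl on a saturated chain carbon, three bonds along the chain from an aromatic carbon. For the measured compounds named here, the only step that bears on this change is a 1.3-fold lower number from compound 1 to compound 2 (0.11 log units; within the scatter), which shows that adding or shifting a small substituent on this ring has so far moved this assay by no more than the scatter. On that basis compound 3 is expected to stay close to compound 2, with a step of a 1.2-fold higher number from compound 2 to compound 3 (0.08 log units; within the scatter), which is no change beyond the scatter. The estimate for compound 3 in this assay is therefore 400 nM, expected to fall between 150 nM and 1100 nM.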

Compound 3, half-maximal inhibitory concentration: 247 nM
Estimate against measurement, compound 3: 1.6-fold (0.21 log units) above; low and high end bracket the measured number.
By their numbers in this assay, from the lowest: compounds 3, 2 and 1 (each within the scatter of the next).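

In this assay, 2-hydroxyphenyl in place of 3-methoxyphenyl, which brings in a hydrogen-bond donor where the group that leaves has none, gives a 1.4-fold lower number from compound 2 to compound 3 (0.13 log units; within the scatter), and adding a hydroxy to the ring at the end of the chain gives a 1.7-fold lower number from compound 1 to compound 3 (0.24 log units; within the scatter). Both steps stay within the scatter, so this end of the side chain now accepts a hydroxy as well as a methoxy without a readable shift, whereas the earlier pair had shown this for methoxy alone and had no group with a hydrogen-bond donor on this ring. Nothing in the available data gives a reason for this flat response, and no supporting measurement bears on it.

Compound 2 and compound 3 differ both in the substituent and in its numbered place on the ring, so these two compounds cannot separate the effect of one from the other. From the compounds shown here alone, whether an amine or a carboxylic acid on this ring, or a longer chain between the ring and the shared core, would move the number beyond the scatter remains open.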